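Swapping a trimethoxyphenyl for a difluorophenyl in a cytotoxicity series

A few compounds are considered here, and "the series" means these few. Any claim that something is new, unique, unknown or untested is made for them only; others in the source may bear on it.

Measured compounds:
Compound 1, `CN(C)CCn1cnnc1-c1cc(Oc2ccc(NC(=O)N/N=C/c3ccc(Cl)cc3)cc2F)ccn1`, gives 1870 nM in an ADME assay on WI-38 cells (Homo sapiens) for cytotoxicity, read by MTT assay, with a stated time of 72 h; a higher number here means a weaker inhibitor, a lower number a stronger inhibitor.
Compound 2, `COc1ccc(/C=N/NC(=O)Nc2ccc(Oc3ccnc(-c4nncn4CCN(C)C)c3)c(F)c2)c(OC)c1`, gives 6630 nM in this assay.
Compound 3, `COc1ccc(/C=N/NC(=O)Nc2ccc(Oc3ccnc(-c4nncn4CCN(C)C)c3)c(F)c2)c(OC)c1OC`, is recorded in this assay as "not determined" (no result reported).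

Compound 3 therefore has no number of its own in this assay and stands only by its structure, which carries a 2,3,4-trimethoxyphenyl where compound 2 carries a 2,4-dimethoxyphenyl. Compound 4, `CN(C)CCn1cnnc1-c1cc(Oc2ccc(NC(=O)N/N=C/c3ccc(F)cc3F)cc2F)ccn1`, differs from compound 3 as follows: 2,4-difluorophenyl in place of 2,3,4-trimethoxyphenyl on a carbon with a double bond to nitrogen.

Going by the values given here, the only measured step that bears on this exchange is a 3.5-fold higher number from compound 1 to compound 2 (0.55 log units; beyond the scatter), which moved from a halogen-bearing phenyl to a methoxy-bearing phenyl. The step to compound 4 runs the other way, from methoxy groups to fluorine, so a lower number, back toward the value of compound 1, is the plausible outcome, though the trimethoxy starting point has no measured anchor. Compound 4 is therefore expected to give about 2000 nM, within 800 nM to 5500 nM.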

Compound 4, half-maximal inhibitory concentration: 5030 nM
Estimate against measurement, compound 4: 2.5-fold (0.40 log units) below, within the range that was stated.
By their numbers in this assay, from the lowest: compound 1; then compounds 4 and 2 (each within the scatter of the next).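

The exchange of 2,4-dimethoxyphenyl for 2,4-difluorophenyl on this carbon with a double bond to nitrogen gives a 1.3-fold lower number from compound 2 to compound 4 (0.12 log units; within the scatter) in this assay and so does not separate the two groups. The exchange of 4-chlorophenyl for 2,4-difluorophenyl gives a 2.7-fold higher number from compound 1 to compound 4 (0.43 log units; beyond the scatter) in this same read-out, leaving compound 1 with the lowest number of the three, and compound 4 goes against any reading that a halogen on this phenyl is enough to bring the number down. Nothing offered here accounts for the gap between the two halogen-bearing compounds.

The step from compound 3 to compound 4 cannot be read, as compound 3 has no number. Open too, going by these compounds, is how a 4-fluorophenyl, a 2,4-dichlorophenyl, or a phenyl carrying an amine or a carboxylic acid would stand at this place.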